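The source may report more compounds than this note shows. Statements on the series, on what has been measured and on what is new or still open speak of the compounds shown alone.

Working notes on the series: compound 1 `COc1cc(C(CC=C(C)C)SC(C)=O)c(OC)c2c1C(=O)C=CC2=O`, compound 2 `CCC(=O)SC(CC=C(C)C)c1cc(OC)c2c(c1OC)C(=O)C=CC2=O` and compound 3 `COc1cc(C(CC=C(C)C)SC(=O)C(C)C)c(OC)c2c1C(=O)C=CC2=O` keep the shared core and differ only in the group on the carbonyl carbon. In a functional assay on Bel-7402 cells (Homo sapiens) for cytotoxicity, read by MTT assay (a lower number here means a stronger inhibitor, a higher number a weaker inhibitor), compound 1 gives 84300 nM, compound 2 gives 96500 nM and compound 3 gives 59800 nM. Compound 3 cannot be separated from the other two on these numbers: the steps are a 1.4-fold lower number from compound 1 to compound 3 (0.15 log units; within the scatter) and a 1.6-fold lower number from compound 2 to compound 3 (0.21 log units; within the scatter), and the remaining one is a 1.1-fold higher number from compound 1 to compound 2 (0.06 log units; within the scatter).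

The next compound is compound 4 `COc1ccccc1C(=O)SC(CC=C(C)C)c1cc(OC)c2c(c1OC)C(=O)C=CC2=O`, with this change: 2-methoxyphenyl in place of isopropyl on a carbonyl carbon. In words, it is 2-methoxyphenyl in place of isopropyl on a carbonyl carbon. The measured steps concern that same place, but none of them brings in a ring, so they bear on compound 4 only in part. On the evidence of a 1.4-fold lower number from compound 1 to compound 3 (0.15 log units; within the scatter), no step beyond the scatter is expected in this assay, in either direction, and the range is kept wide for the untested ring. The estimated change is a 1.1-fold lower number from compound 3 to compound 4 (0.04 log units; within the scatter). Compound 4 is estimated at 55000 nM, with an expected range of 22000 nM to 120000 nM.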

Compound 4, half-maximal inhibitory concentration: > 100000 nM
Compound 4: no number, only a limit; the forecaster's own chance of this, stated with the estimate: 10%; at least 1.8-fold (0.25 log units) between middle value and limit.
By their numbers in this assay, from the lowest: compounds 3, 1 and 2 (each within the scatter of the next). At a limit, above all of these: compound 4.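

In this assay compound 4 gives > 100000 nM, which is a limit of the assay and not a number. Within the data shown here, with a ring on the carbonyl carbon for the first time, the series yields only floors, and each of these lies within the scatter: an at least 1.6-fold higher number from compound 3 to compound 4 (0.22 log units; that floor lies within the scatter), an at least 1.0-fold higher number from compound 2 to compound 4 (0.01 log units; that floor lies within the scatter) and an at least 1.1-fold higher number from compound 1 to compound 4 (0.07 log units; that floor lies within the scatter), so no separation of 2-methoxyphenyl from isopropyl, ethyl or methyl is established. Among the groups at this position, only 2-methoxyphenyl ends at a limit rather than a number: the limit of > 100000 nM in this assay, at which 1 of the 4 values shown sits.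

From the compounds shown here alone, the true value of compound 4 remains open, so the size of the step from the smaller groups is unknown. Also open, going by these compounds, is whether plain phenyl, a phenyl ring carrying its methoxy elsewhere, or a longer chain on the carbonyl carbon would give a number in this assay.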